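Trimming the heteroaryl methoxy group of compound 2

This account rests on a few compounds, and the source may have more. Where it says the series, first, only, none or still open, it means among the compounds named here.

Compound 1 `CC(C)(C)Sc1c(CC(C)(C)C(=O)O)n(Cc2ccc(Cl)cc2)c2ccc(OCc3ccc4cccnc4n3)cc12` — 6 nM
Compound 2 `CC(C)(C)Sc1c(CC(C)(C)C(=O)O)n(Cc2ccc(Cl)cc2)c2ccc(OCc3nc4ccccc4o3)cc12` — < 7 nM

Of the compounds shown here, two have been measured. In a functional assay for inhibition, with Homo sapiens as the target (on this read-out higher numbers stand for weaker inhibition and lower numbers for stronger inhibition), compound 1 gives 6 nM. In this assay compound 2 gives < 7 nM, which is a limit of the assay and not a number. The step that the limit leaves unreadable from compound 1 to compound 2 therefore cannot be sized; compound 2 stands at the limit, as noted in the limit of < 7 nM in this assay, at which 1 of the 2 values shown sits, so its true value is only known to lie on that side. The unmeasured compound 3 `CC(C)(C)Sc1c(CC(C)(C)C(=O)O)n(Cc2ccc(Cl)cc2)c2ccc(OCc3ccncc3)cc12` differs from compound 2 by pyridin-4-yl in place of 1,3-benzoxazol-2-yl on a saturated chain carbon bound to an oxygen on an aromatic ring. No measured step reads on this change, since the only step shown is unreadable. Compound 3 is expected to sit somewhat weaker than compound 2, with the step of an at least 5.7-fold higher number from compound 2 to compound 3 (0.75 log units; beyond the scatter) estimated as modest and uncertain. Compound 3 is estimated at 40 nM, within a range from 6 nM to 300 nM.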

Compound 3, half-maximal inhibitory concentration: 6 nM
Compound 3: the middle estimate sits 6.7-fold (0.82 log units) above what was measured, and the stated range covers the measured number.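

In this assay, pyridin-4-yl in place of the two-ring group of compound 1 gives no change at the digits printed from compound 1 to compound 3 (within the scatter). On a saturated chain carbon bound to an oxygen on an aromatic ring, a single six-membered aromatic ring therefore holds the read-out as well as the larger group does, at least for this pair. Compound 2 carries a limit and not a number, so the steps that involve it cannot be read: the limit of < 7 nM in this assay, at which 1 of the 3 values shown sits.

As far as these compounds go, whether the 1,3-benzoxazol-2-yl group of compound 2 differs at all from the other two groups stays open. So does whether a phenyl ring, a pyridin-2-yl group or a small chain such as methyl would hold the value at this place.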